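The source may hold more compounds than are shown below. What is called first, only, known or untested is meant among the compounds shown, and "the series" means these compounds.

Measured so far in an ADME assay on MRC5 cells (Homo sapiens) for antiproliferative activity, read by fluorescence and resazurin assay, with a stated time of 68 h; a higher number here means that more compound is needed for the effect, a lower number that less compound is needed:
- compound 1 `Cc1ccc(-c2cc(C(=O)Nc3cccnc3)c3cc(Br)ccc3n2)cc1`: 21000 nM
- compound 2 `Cc1ccc(-c2cc(C(=O)NCCN(C)C)c3cc(Cl)ccc3n2)cc1`: 9000 nM

Of these two numbers, the lower belongs to compound 2 at 9000 nM, and its gap to compound 1 at 21000 nM lies beyond the scatter. For the measured compounds named here, no measured pair differs in one place only, so no single-change step is available as a guide.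

Next in line is compound 3 `Cc1ccc(-c2cc(C(=O)NCCN3CCN(C)CC3)c3cc(Cl)ccc3n2)cc1`, not yet measured. Its difference from compound 2 counts as follows: 4-methylpiperazin-1-yl in place of dimethylamino on a saturated chain carbon, two bonds along the chain from an amide-type nitrogen. In short, 4-methylpiperazin-1-yl stands in place of dimethylamino on a saturated chain carbon, two bonds along the chain from an amide-type nitrogen.

Going by the values given here, the series holds no measured precedent for this change, so the expectation takes compound 2 at 9000 nM as its anchor. No step beyond the scatter is expected in this assay, and the range stays wide in both directions. The expected step is a 1.1-fold higher number from compound 2 to compound 3 (0.05 log units; within the scatter). For compound 3 the estimated value is 10000 nM, with an expected range of 4000 nM to 25000 nM.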

Compound 3, half-maximal effective concentration: 8000 nM
Compound 3: the middle estimate sits 1.3-fold (0.10 log units) above what was measured; measured number inside the range.
By their numbers in this assay, from the lowest: compounds 3 and 2 (each within the scatter of the next); then compound 1.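

In this assay, 4-methylpiperazin-1-yl in place of dimethylamino on a saturated chain carbon, two bonds along the chain from an amide-type nitrogen, gives a 1.1-fold lower number from compound 2 to compound 3 (0.05 log units; within the scatter). For the compounds shown here, this is the first single-place comparison, and it shows that the dimethylamino group at the end of the 2-(dimethylamino)ethyl chain can be exchanged for a group carrying a six-membered non-aromatic ring with 2 hetero atoms without a step beyond the scatter in this read-out. No supporting evidence is available to say why compound 2 and compound 3 read alike.

A single exchange at this chain end leaves open whether the flat response extends to other end groups, such as morpholin-4-yl, a primary amine or a carboxylic acid, or to a longer chain between the amide-type nitrogen and the end group. Compound 1 differs from compound 2 and from compound 3 in more than one place, so the contribution of each of its differences to the reading in this assay remains unresolved.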